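The source may report more compounds than this note shows. Statements on the series, on what has been measured and on what is new or still open speak of the compounds shown alone.

Compound 1 `C[C@@H]1CN(c2cccc3c2C[C@H](CN(C)[C@H]2CCCc4cccnc42)NC3)C[C@H](C)N1`, compound 2 `CN1CCN(c2cccc3c2C[C@H](CN(C)[C@H]2CCCc4cccnc42)NC3)CC1` and compound 3 `C[C@@H]1CN(c2cccc3c2C[C@H](CN(C)[C@H]2CCCc4cccnc42)NC3)C[C@H](C)N1C` share a core and were tested in an ADME assay on microsomes from liver (Homo sapiens) for metabolic stability, read by LC-MS, with a stated time of 10 min; on this read-out higher numbers stand for a more stable compound and lower numbers for a less stable compound. In this assay compound 1 gives 100%, compound 2 gives 75.8% and compound 3 gives 24.6%. The core of compound 1 differs from the core of compound 2 by 4-methylpiperazin-1-yl in place of 3,5-dimethylpiperazin-1-yl on an aromatic carbon, and that step made a number 24.2 percentage points lower from compound 1 to compound 2 (beyond the scatter). From compound 1 to compound 3 the change is methyl in place of hydrogen on an amine nitrogen in a ring, with a step of a number 75.4 percentage points lower from compound 1 to compound 3 (beyond the scatter). Compound 4 `CN1CCN(c2cccc3c2C[C@H](CN(C)[C@H]2CCCc4cccnc42)N(C)C3)CC1` has not yet been measured in this assay. It differs from compound 2 by methyl in place of hydrogen on an amine nitrogen in a ring. Among the compounds with values here, this is the same kind of change as the one from compound 1 to compound 3, but not the same: there the nitrogen sits in a six-membered non-aromatic ring with 2 nitrogen, next to two ring atoms that each bear a methyl group, whereas in compound 4 it sits in a six-membered non-aromatic ring with 1 nitrogen, part of a fused or bridged system of two rings, next to the ring atom that bears a large group. A drop is expected for compound 4 as well, of about a number 40.8 percentage points lower from compound 2 to compound 4 (beyond the scatter), resting on the step of a number 75.4 percentage points lower from compound 1 to compound 3 (beyond the scatter). The differing place leaves the size uncertain. Compound 4 is therefore estimated at 35%, expected to lie between 15% and 60%.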

Compound 4, percent of the compound remaining: 83.3%
Beside the measured number, compound 4's estimate is 48.3 percentage points below it; the measured number lies above the stated range.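

In this assay, putting a methyl on the amine nitrogen in the ring of compound 2 gave a step of a number 7.5 percentage points higher from compound 2 to compound 4 (within the scatter), so the read-out does not tell these two compounds apart. A methyl placed on an amine nitrogen in a ring therefore cannot be expected to carry the same result from one core to another in this series, since the two steps shown clearly disagree: the same change on two cores in this assay, a number 75.4 percentage points lower (beyond the scatter) from compound 1 to compound 3 and a number 7.5 percentage points higher (within the scatter) from compound 2 to compound 4, 82.9 percentage points apart, beyond the scatter of two such steps With only these two pairs, which differ both in which ring nitrogen takes the methyl and in the rest of the core, the data do not show which of those differences matters, or why.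

On these data alone, it remains open whether a larger group on the same ring nitrogen of compound 2, such as an ethyl or an acetyl, would match the methyl. Also open, as far as these compounds go, is how this methyl would fare with 3,5-dimethylpiperazin-1-yl on the aromatic carbon in place of 4-methylpiperazin-1-yl.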